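The source may hold more compounds than are shown below. What is called first, only, known or untested is meant among the compounds shown, and "the series" means these compounds.

Compound 1 `C=C(C)C(=O)c1ccc(OCc2nc(C)no2)c(C)c1C` and compound 2 `C=C(C)C(=O)c1ccc(OCc2nc(-c3ccccc3)no2)c(C)c1C` share one core and differ in a single place: phenyl in place of methyl on an aromatic carbon. In a functional assay on HL-60 cells (Homo sapiens) for inhibition (on this read-out higher numbers stand for weaker inhibition of growth and lower numbers for stronger inhibition of growth), compound 1 gives 3200 nM and compound 2 gives 3500 nM. The step is a 1.1-fold higher number from compound 1 to compound 2 (0.04 log units; within the scatter). Compound 3 `C=C(C)C(=O)c1ccc(OCc2nc(C)no2)cc1Br` rests on another core; the difference between the two cores is not broken down here. In this assay compound 3 gives 3200 nM. Compound 4 `C=C(C)C(=O)c1ccc(OCc2nc(-c3ccccc3)no2)cc1Br` has not yet been measured; it differs from compound 3 by phenyl in place of methyl on an aromatic carbon, the same change that leads from compound 1 to compound 2. Because the earlier step of a 1.1-fold higher number from compound 1 to compound 2 (0.04 log units; within the scatter) stays within the scatter, a step of about the same size is expected here, a 1.1-fold higher number from compound 3 to compound 4 (0.04 log units; within the scatter). On that basis compound 4 is estimated at 3500 nM in this assay, most likely between 1800 nM and 7000 nM.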

Compound 4, concentration for 50% growth inhibition: 7900 nM
Estimate against measurement, compound 4: 2.3-fold (0.35 log units) below; measured number above the stated range.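

In this assay, phenyl in place of methyl on an aromatic carbon gives a 2.5-fold higher number from compound 3 to compound 4 (0.39 log units; beyond the scatter), a modest step, whereas the same change on the core of compound 1 gives a 1.1-fold higher number from compound 1 to compound 2 (0.04 log units; within the scatter). Set side by side, the two steps do not differ by more than repeated measurements allow: the same change on two cores in this assay, a 1.1-fold higher number (0.04 log units; within the scatter) from compound 1 to compound 2 and a 2.5-fold higher number (0.39 log units; beyond the scatter) from compound 3 to compound 4, 2.3-fold (0.35 log units) apart, within the scatter of two such steps. The change therefore carries across these two cores as far as these data can tell, but two pairs cannot show that it will behave alike on other cores. Among the compounds shown here, only one of the two steps lies beyond the scatter, and these data do not show what sets the two steps apart.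

Still open, going by these compounds, is how other groups on the same ring carbon would compare, such as ethyl, cyclohexyl or an amine. On these data alone, it is also open whether a phenyl bearing fluorine or methoxy would fit the same picture.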